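Methyl on the phenoxy ring of compound 2

This account rests on a few compounds, and the source may have more. Where it says the series, first, only, none or still open, it means among the compounds named here.

In a functional assay on MIA PaCa-2 cells (Homo sapiens) for antiproliferative activity, read by MTT assay, with a stated time of 72 h (a lower number here means that less compound is needed, a higher number that more compound is needed for the effect), compound 1 `Cc1nn(Cc2ccccc2C(N)=O)c(C)c1NC(=O)c1ccc(COc2ccccc2)cc1` gives 42000 nM, compound 2 `CNC(=O)c1cccc(Cn2nc(C)c(NC(=O)c3ccc(COc4ccccc4)cc3)c2C)c1` gives 6200 nM and compound 3 `Cc1nn(Cc2cccc(C(=O)NC(C)C)c2)c(C)c1NC(=O)c1ccc(COc2ccccc2)cc1` gives 8900 nM. Compound 2 holds the lowest number of the three; its gap to compound 3 lies within the scatter, while the steps of a 6.8-fold lower number from compound 1 to compound 2 (0.83 log units; beyond the scatter) and a 4.7-fold lower number from compound 1 to compound 3 (0.67 log units; beyond the scatter) are modest and beyond it. Compound 4 `CNC(=O)c1cccc(Cn2nc(C)c(NC(=O)c3ccc(COc4ccc(C)cc4)cc3)c2C)c1` differs from compound 2 by methyl in place of hydrogen on an aromatic carbon. Among the measured compounds shown here, no measured step touches the phenoxymethyl end: all three steps seen sit on the group on the saturated chain carbon bound to the aromatic nitrogen, so nothing here bears on this change, and a step within the scatter in this assay is expected. Compound 4 is therefore estimated at 6200 nM, range 2500 nM to 15000 nM, an expected step of no change at the digits printed from compound 2 to compound 4 (within the scatter).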

Compound 4, half-maximal effective concentration: 2600 nM
The estimate for compound 4 lay 2.4-fold (0.38 log units) above the measured number; the range from low to high includes it.
By their numbers in this assay, from the lowest: compound 4; then compounds 2 and 3 (each within the scatter of the next); then compound 1.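

In this assay, among the compounds shown here, the phenoxy end of the series proves responsive: phenoxy to 4-methylphenoxy gives a 2.4-fold lower number from compound 2 to compound 4 (0.38 log units; beyond the scatter) as the only measured step away from the group on the saturated chain carbon. A single methyl on the aromatic carbon para to a large group is thus enough to move the number beyond the scatter. Nothing available accounts for this step.

From the compounds shown here alone, whether the step is specific to methyl remains open, since ethyl, methoxy or chlorine at this place would test it. Also open, going by these compounds, is whether 4-methylphenoxy gives a similar step with the isopropyl amide of compound 3.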